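Swapping a cyclohexyl amine for a bromophenyl amine

The compounds below may be only part of what the source reports. "The series", "measured", "known", "first", "only" and "open" are said of these compounds alone.

Measured so far:
Compound 1 `O=C(Nc1cc(C(F)(F)F)ccc1NC1CCCCC1)c1ccccc1` – "not active" (no number reported)
Compound 2 `O=C(Nc1cc(C(F)(F)F)ccc1NC1CCCCC1)c1cccnc1` – "not active" (no number reported)
Compound 3 `O=C(Nc1cc(C(F)(F)F)ccc1NC1CCCCC1)c1ccncc1` – 80900 nM

Three compounds share one core and differ only in the aromatic ring attached to the amide carbonyl. In a functional assay on Jurkat cells (Homo sapiens) for cytotoxicity, read by MTT assay, with a stated time of 48 h (on this read-out lower numbers stand for stronger inhibition and higher numbers for weaker inhibition), compound 1 gives "not active" (no number reported), reported without a number. In this assay compound 2 likewise gives "not active" (no number reported), again with no number attached, so it stands alongside compound 1 as one of two entries for which nothing more than "not active" is known. Only compound 3 carries a measured value, and in this assay compound 3 gives 80900 nM, which is a weak result.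

Compound 4 `O=C(Nc1cc(C(F)(F)F)ccc1Nc1ccc(Br)cc1)c1cccnc1` keeps the pyridine amide of compound 2 but changes the other amine substituent: 4-bromophenyl in place of cyclohexyl on a nitrogen on an aromatic ring. For the measured compounds named here, no measured pair shows what this change does, so there is no step to lean on. Given that compound 2 showed nothing measurable in this assay, the expectation for compound 4 is also weak activity, with a fair chance that no number is reported at all. Compound 4 is estimated at 60000 nM in this assay, with a range from 10000 nM to 300000 nM.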

Compound 4, half-maximal inhibitory concentration: 17800 nM
Estimate against measurement, compound 4: 3.4-fold (0.53 log units) above; the range from low to high includes it.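

Compound 2 carries no number in this assay, while compound 4 gives 17800 nM there, so no step can be read between them. The compounds shown leave open how large the effect of 4-bromophenyl in place of cyclohexyl is, and whether it would hold with the amide rings of compound 1 and compound 3. No measured evidence offers an explanation for this result.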